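Working notes on efficacy: from compound 2 to compound 3

A few compounds are considered here, and "the series" means these few. Any claim that something is new, unique, unknown or untested is made for them only; others in the source may bear on it.

compound 1 `CS(=O)(=O)Nc1cccc(-c2nc(C(c3ccc(F)cc3)c3ccc(F)cc3)sc2CC(=O)O)c1`: 80%
compound 2 `O=C(O)Cc1sc(C(c2ccc(F)cc2)c2ccc(F)cc2)nc1-c1ccnc(F)c1`: 80%

Both values come from an in vitro functional assay on HEK285-7 cells for antagonist activity at prostaglandin D2 receptor 2 (Homo sapiens), read by BRET and beta-arrestin recruitment; a lower number here means a smaller maximal response, a higher number a larger maximal response. Compound 2 stands level with compound 1: the step of no change at the digits printed from compound 1 to compound 2 (within the scatter), 2-fluoropyridin-4-yl in place of 3-(methanesulfonamido)phenyl, lies within the scatter. Compound 3 `O=C(O)Cc1sc(C(c2ccc(F)cc2)c2ccc(F)cc2)nc1-c1cc(F)nc(F)c1` differs from compound 2 by fluoro in place of hydrogen on an aromatic carbon. Within the data shown here, the only step measured, no change at the digits printed from compound 1 to compound 2 (within the scatter), left the maximal response unchanged; no step beyond the scatter is known in this assay (this assay), so none is expected here either. Compound 3 is expected to give 80%, in the range 68% to 92%. The expected step is no change at the digits printed from compound 2 to compound 3 (within the scatter).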

Compound 3, largest response reached (reported as efficacy), in percent of the reference or control that the assay uses: 80%
Estimate against measurement, compound 3: no gap at the digits printed; measured number inside the range.
By their numbers in this assay, from the lowest: compounds 1, 2 and 3 (each within the scatter of the next).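

In this assay, fluoro in place of hydrogen next to the ring nitrogen gives no change at the digits printed from compound 2 to compound 3 (within the scatter) here, so this position takes a second fluoro without a step beyond the scatter. The 2,6-difluoropyridin-4-yl group in place of 3-(methanesulfonamido)phenyl likewise gives no change at the digits printed from compound 1 to compound 3 (within the scatter) in this series. No measured evidence bears on this result. On these data alone, whether an amine or a methoxy group at this position would move the maximal response stays open, as does whether any change gives a step beyond the scatter.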